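The compounds below may be only part of what the source reports. "The series", "measured", "known", "first", "only" and "open" are said of these compounds alone.

Measured compounds:
- compound 1 `CC1CCN(c2nc(C(F)(F)F)ccc2CNC(=O)Nc2ccc3ccccc3n2)CC1`: "not active" (no number reported)
- compound 2 `CC1CCN(c2nc(C(F)(F)F)ccc2CNC(=O)Nc2cccc3cnccc23)CC1`: 0.2 nM
- compound 3 `CC1CCN(c2nc(C(F)(F)F)ccc2CNC(=O)Nc2cncc3ccccc23)CC1`: 1.8 nM

Going by the values given here, in an assay on isolated protein for antagonist activity at transient receptor potential cation channel subfamily V member 1 (Homo sapiens), read by FLIPR (on this read-out higher numbers stand for weaker inhibition and lower numbers for stronger inhibition), compound 1 gives "not active" (no number reported); no single number stands for it, so no step from compound 1 can be computed. Compound 4 `CC1CCN(c2nc(C(F)(F)F)ccc2CNC(=O)Nc2nccc3ccccc23)CC1` differs from compound 1 in one place: isoquinolin-1-yl in place of quinolin-2-yl on an amide-type nitrogen. Among the compounds with values here, no measured step covers this exact exchange. Within the data shown here, the only step of related kind is the rearrangement within the isoquinoline in a 9.0-fold higher number from compound 2 to compound 3 (0.95 log units; beyond the scatter), which shows that moving the ring nitrogen alone can shift this assay beyond the scatter. Compound 2 and compound 3 both give strong inhibition, compound 1 none; compound 4 is expected to fall between these outcomes, with wide uncertainty. For compound 4 in this assay the expected value is 30 nM, range 3 nM to 1000 nM.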

Compound 4, inhibition constant: "not active" (no number reported)
The entry for compound 4 holds no number; no gap can be computed for the estimate.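

Going by these compounds alone, compound 1 and compound 4 both carry no number in this assay, so no step between them can be read. No evidence at hand bears on this result. The compounds shown leave open what separates quinolin-2-yl and isoquinolin-1-yl from the isoquinolin-5-yl of compound 2 and the isoquinolin-4-yl of compound 3.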